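The source may hold more compounds than are shown below. What is called first, only, known or untested is meant among the compounds shown, and "the series" means these compounds.

Among the compounds with values here, compound 1 `O=C1C(Nc2ccc(I)cc2)=CC(=O)c2c1nc1n2[C@H]2OC[C@@H](O)[C@H]2OC1` is the only compound of this set with a measured number: in a functional assay on ECa-109 cells for inhibition, with ECa-109 cell line (Homo sapiens) as the target, read by sulforhodamine B assay (a lower number here means a stronger inhibitor, a higher number a weaker inhibitor), compound 1 gives 2530 nM. Compound 2 `O=C1C=C(N2CCC2)C(=O)c2c1nc1n2[C@H]2OC[C@@H](O)[C@H]2OC1` reaches only a limit of the assay, giving > 16000 nM. Compound 3 `CCCN(CCC)C1=CC(=O)c2nc3n(c2C1=O)[C@H]1OC[C@@H](O)[C@H]1OC3` likewise reaches only a limit, giving > 16000 nM. The step that the two limits leave unreadable from compound 2 to compound 3 is therefore unreadable, and the two limits together make up (the limit of > 16000 nM in this assay, at which 2 of the 3 values shown sit). Compound 4 `CCOc1ccccc1NC1=CC(=O)c2c(nc3n2[C@H]2OC[C@@H](O)[C@H]2OC3)C1=O` differs from compound 1 by 2-ethoxyphenyl in place of 4-iodophenyl on an amine nitrogen. No measured step bears on this exchange: the single step shown is itself unreadable, and no other pair in the set varies the group on that amine nitrogen while a number is known at both ends. With nothing to point either way, compound 4 is expected to stay close to compound 1, with a step of a 1.2-fold higher number from compound 1 to compound 4 (0.07 log units; within the scatter) that is not expected to exceed the usual scatter. Compound 4 is estimated at 3000 nM, within a range from 800 nM to 12000 nM.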

Compound 4, half-maximal inhibitory concentration: 4320 nM
Compound 4: the middle estimate sits 1.4-fold (0.16 log units) below what was measured; measured number inside the range.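

In this assay the exchange gives a 1.7-fold higher number from compound 1 to compound 4 (0.23 log units; within the scatter), which lies within the scatter, so on this amine nitrogen 2-ethoxyphenyl and 4-iodophenyl cannot be told apart. Within the data shown here, compound 1 and compound 4 also give the first step in the set with a number at both ends, as the only earlier step cannot be read. Nothing measured here bears on this result, and no cause can be given for it.

The compounds shown leave open whether an unsubstituted phenyl, a benzyl or a cyclohexyl group on this amine nitrogen would also stay within the scatter of compound 1. They also leave open how a 4-ethoxyphenyl or a 2-iodophenyl group would read, and with it whether the place of the substituent on the aromatic ring matters apart from its identity.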